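Cyclopentyl in Place of Cyclopropyl on the Ring Nitrogen

This account rests on a few compounds, and the source may have more. Where it says the series, first, only, none or still open, it means among the compounds named here.

Compound 3 `Cc1cc(NC(=O)Cn2nnc(-c3ccccc3)n2)n(C2CC2)n1` stands apart from the other two: in an assay on HEK293 cells for activation of Kir3.1/Kir3.2 (Homo sapiens), read by thallium flux (on this read-out lower numbers stand for an effect already at smaller amounts and higher numbers for an effect only at larger amounts of compound), compound 3 gives > 5000 nM, which is a limit of the assay and not a number (the limit of > 5000 nM in this assay, at which 1 of the 3 values shown sits). Compound 1 `Cc1cc(NC(=O)Cn2nnc(-c3ccccc3)n2)n(C2CCOCC2)n1` gives 435 nM in this assay, and compound 2 `Cc1cc(NC(=O)Cn2nnc(-c3ccccc3)n2)n(C(C)C)n1` gives 556 nM. Compound 4 `Cc1cc(NC(=O)Cn2nnc(-c3ccccc3)n2)n(C2CCCC2)n1` differs from compound 3 by cyclopentyl in place of cyclopropyl on an aromatic nitrogen. Among the measured compounds shown here, the steps that bear on this change are an at least 11-fold higher number from compound 1 to compound 3 (1.06 log units; beyond the scatter) and an at least 8.9-fold higher number from compound 2 to compound 3 (0.95 log units; beyond the scatter), both large losses on arrival at cyclopropyl, whereas a 1.3-fold higher number from compound 1 to compound 2 (0.11 log units; within the scatter) shows little difference between the two other groups on that nitrogen. Moving away from cyclopropyl is therefore expected to recover much of that loss, an at least 7.1-fold lower number from compound 3 to compound 4 (0.85 log units; beyond the scatter). Compound 4 is estimated to give about 700 nM, with a range from 250 nM to 2500 nM.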

Compound 4, half-maximal effective concentration: 163 nM
Estimate against measurement, compound 4: 4.3-fold (0.63 log units) above, and the stated range ends above it.
By their numbers in this assay, from the lowest: compound 4; then compounds 1 and 2 (each within the scatter of the next). At a limit, above all of these: compound 3.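

Compound 3 stands at a limit and not at a number in this assay: the limit of > 5000 nM in this assay, at which 1 of the 4 values shown sits. The change to cyclopentyl brings an at least 30-fold lower number from compound 3 to compound 4 (1.48 log units; beyond the scatter), so the earlier picture of a loss at cyclopropyl now has a clear counterpart. Cyclopentyl also goes beyond the two groups that had looked alike, with a 3.4-fold lower number from compound 2 to compound 4 (0.53 log units; beyond the scatter) and a 2.7-fold lower number from compound 1 to compound 4 (0.43 log units; beyond the scatter).

Still open, as far as these compounds go, is whether a larger carbon ring such as cyclohexyl would lower the number further. The effect of a ring amine such as piperidin-4-yl on this nitrogen is also unknown.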